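This account rests on a few compounds, and the source may have more. Where it says the series, first, only, none or still open, it means among the compounds named here.

The measured compounds:

compound 1, `CC1(c2ccc(NC(c3ccncc3)c3nnnn3C(C)(C)C)cc2)NC(=O)c2ccccc2N1`: "not determined" (no result reported)
compound 2, `CC1(c2ccc(Nc3nc(NCc4ccco4)nc(NCc4ccco4)n3)cc2)NC(=O)c2ccccc2N1`: "not determined" (no result reported)
compound 3, `CC1(c2ccc(Nc3nc(N4CCc5ccccc5C4)nc(N4CCc5ccccc5C4)n3)cc2)NC(=O)c2ccccc2N1`: > 400000 nM

In an ADME assay on Vero cells (Chlorocebus sabaeus) for cytotoxicity, read by MTT assay, with a stated time of 72 h (on this read-out lower numbers stand for higher toxicity in this test and higher numbers for lower toxicity in this test), compound 1 has no single number, and compound 2 likewise has none. Within the data shown here, the only reading comes from compound 3, and it is a limit of this assay rather than a number; that is the situation described by the limit of > 400000 nM in this assay, at which 1 of the 3 values shown sits. Compound 1 therefore stands nowhere on a scale of numbers here, and no measured step between any two of these compounds can be sized.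

The unmeasured compound 4, `CC1(c2ccc(NC(c3ccc(Br)cc3)c3nnnn3C(C)(C)C)cc2)NC(=O)c2ccccc2N1`, differs from compound 1 in one place: 4-bromophenyl in place of pyridin-4-yl on a saturated chain carbon bound to an aromatic carbon and a nitrogen on an aromatic ring. Among the measured compounds shown here, since compound 1 has no reading in this assay, no step from it can be expected in either direction; the expectation for compound 4 rests on compound 3 alone, whose value is a limit, so a result beyond the scatter in either direction is not anticipated. Compound 4 is estimated at 300000 nM, with a range from 60000 nM to 1500000 nM, and a sizeable chance that only a limit is reported.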

Compound 4, half-maximal cytotoxic concentration: > 400000 nM
Compound 4 gave a limit, no number (the forecaster's own chance of this, stated with the estimate: 50%); middle value at least 1.3-fold (0.12 log units) from the limit.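

In this assay compound 4 gives > 400000 nM, a limit and not a number. Among these compounds, compound 1 has no single number there, so no step between compound 1 and compound 4 can be read. The compounds shown leave open whether 4-bromophenyl in place of pyridin-4-yl changes the read-out at all.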